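The source may report more compounds than this note shows. Statements on the series, on what has been measured and on what is new or still open speak of the compounds shown alone.

Compound 3 `Cc1cccc(NC(=O)C(=O)O)c1C#N` stands lowest of the three measured compounds in a functional assay on the whole organism for inhibition, with Rattus norvegicus as the target, at a dose of 1 mg/kg by the oral route (a higher number here means more inhibition at the dose given (going by the name of the read-out), a lower number less inhibition), where compound 3 gives 32.3%. Compound 1 `CN(C)c1cccc(NC(=O)C(=O)O)c1C#N` gives 54.7% and compound 2 `CCNc1cccc(NC(=O)C(=O)O)c1C#N` gives 58.9%; the step of a number 4.2 percentage points higher from compound 1 to compound 2 (within the scatter) lies within the scatter, whereas a number 22.4 percentage points lower from compound 1 to compound 3 (beyond the scatter) and a number 26.6 percentage points lower from compound 2 to compound 3 (beyond the scatter) both fall beyond it. Compound 4 `COC(=O)c1cccc(NC(=O)C(=O)O)c1C#N` differs from compound 3 by methoxycarbonyl in place of methyl on an aromatic carbon. For the measured compounds named here, no measured step places methoxycarbonyl on that aromatic carbon, so the two steps onto compound 3 are the only guide, and they show only that methyl sits lowest of the three groups tried there. The account therefore expects for compound 4 a step of a number 9.7 percentage points higher from compound 3 to compound 4 (within the scatter), not clearly beyond the scatter in either direction. Compound 4 is estimated at 42%, with a range from 22% to 62%.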

Compound 4, a percentage reported as inhibition, in the whole organism at one dose (the size of the read-out at that dose, not a potency): 24.5%
The estimate for compound 4 lay 17.5 percentage points above the measured number; low and high end bracket the measured number.
By their numbers in this assay, from the lowest: compounds 4 and 3 (each within the scatter of the next); then compounds 1 and 2 (each within the scatter of the next).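

In this assay, replacing methyl with methoxycarbonyl on this aromatic carbon, ortho to a cyano group, gives a number 7.8 percentage points lower from compound 3 to compound 4 (within the scatter), so the larger group, with its two hydrogen-bond acceptors, does not separate from methyl. The amino groups stand clearly apart, with a number 34.4 percentage points lower from compound 2 to compound 4 (beyond the scatter) and a number 30.2 percentage points lower from compound 1 to compound 4 (beyond the scatter), and among these four compounds the higher numbers belong only to the two carrying nitrogen on this carbon. Nothing available explains this difference. Going by these compounds, whether an unsubstituted amine or a carboxylic acid here would group with compound 1 and compound 2 or with compound 3 and compound 4 remains open.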